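Amine variation three bonds from the aryl ether oxygen

The source may hold more compounds than are shown below. What is called first, only, known or untested is meant among the compounds shown, and "the series" means these compounds.

Compound 1 `O=C1CCc2ccc(OCCCN3CCCCC3)cc2N1Cc1ccccc1` carries piperidin-1-yl on a saturated chain carbon, three bonds along the chain from an oxygen on an aromatic ring. Within the data shown here, in an assay on cell membranes (strain Dunkin Hartley) for displacement of a labelled ligand from Sigma non-opioid intracellular receptor 1 (Cavia porcellus), read by scintillation counting, with a stated time of 180 min (on this read-out higher numbers stand for weaker inhibition and lower numbers for stronger inhibition), compound 1 gives 1.84 nM, the lowest of the two numbers measured so far. Compound 2 `CN1CCN(CCCOc2ccc3c(c2)N(Cc2ccccc2)C(=O)CC3)CC1` differs from it only in the amine; in this assay compound 2 gives 4.3 nM. Among the measured compounds shown here, the single measured step, a 2.3-fold higher number from compound 1 to compound 2 (0.37 log units; beyond the scatter), shows that putting 4-methylpiperazin-1-yl in place of piperidin-1-yl costs only a little.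

Compound 3 `CCN(CC)CCCOc1ccc2c(c1)N(Cc1ccccc1)C(=O)CC2` is not yet measured. It differs from compound 1 by diethylamino in place of piperidin-1-yl on a saturated chain carbon, three bonds along the chain from an oxygen on an aromatic ring; read one bond further out, 3-(piperidin-1-yl)propyl becomes 3-(diethylamino)propyl. For the measured compounds named here, only the step from compound 1 to compound 2 bears on this change, and it was modest, so a step of similar or smaller size is expected in this assay, most likely toward a somewhat higher number, with an outcome within the scatter also plausible. Compound 3 is therefore expected to give 2.6 nM in this assay, with a range of 1 nM to 6.5 nM, which corresponds to an expected step of a 1.4-fold higher number from compound 1 to compound 3 (0.15 log units; within the scatter).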

Compound 3, inhibition constant: 39.4 nM
The estimate for compound 3 lay 15-fold (1.18 log units) below the measured number, outside the stated range (above it).
By their numbers in this assay, from the lowest: compound 1; then compound 2; then compound 3.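

In this assay this position proves much less forgiving than the earlier comparison of two ring-bearing amines could show: diethylamino, which has no ring, in place of piperidin-1-yl gives a 21-fold higher number from compound 1 to compound 3 (1.33 log units; beyond the scatter) and is a large step. Set against 4-methylpiperazin-1-yl, the same group gives a 9.2-fold higher number from compound 2 to compound 3 (0.96 log units; beyond the scatter) and so also falls behind the second ring-bearing amine, which means that among these three compounds both ring-bearing amines give lower numbers than the open-chain amine, with no compound going against this. Nothing measured here accounts for the size of this loss, and the change from piperidin-1-yl to diethylamino alters the ring and the heavy-atom count together, so these two differences cannot be told apart.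

Still open, from the compounds shown here alone, is whether a ring at this position is what matters, or only particular amines: pyrrolidin-1-yl, azepan-1-yl, morpholin-4-yl and dimethylamino on the same propyl chain would each bear on that question. The compounds shown also leave open how a longer chain carrying piperidin-1-yl would read in this assay.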